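Swapping a phenoxy for fluoro: cytotoxicity outlook

The source may hold more compounds than are shown below. What is called first, only, known or untested is meant among the compounds shown, and "the series" means these compounds.

Measured compounds in an ADME assay on HEK293 cells (Homo sapiens) for cytotoxicity, read by CellTiter-Glo and resazurin assay, with a stated time of 72 h; a lower number here means that less compound is needed, a higher number that more compound is needed for the effect:
compound 1 `CC(C)COc1cccc(-c2ccc(C(=O)N(Cc3cccc(OCCCCCC(=O)O)c3)C(C)C)cc2)c1`, a limit of > 26000 nM.
compound 2 `CC(C)N(Cc1cccc(OCCCCCC(=O)O)c1)C(=O)c1ccc(-c2cccc(Oc3ccccc3)c2)cc1`, a limit of > 18700 nM.
compound 3 `CC(C)N(Cc1cccc(OCCCCCC(=O)O)c1)C(=O)c1ccc(-c2ccc3c(c2)OCCO3)cc1`, a limit of > 21900 nM.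

All three values are limits rather than numbers, so none of the compounds reached the effect within the tested range. Compound 2 therefore stands only at a limit, as do the two others. The two measured steps, a step that the two limits leave unreadable from compound 1 to compound 2 and a step that the two limits leave unreadable from compound 1 to compound 3, cannot be read in size because both ends sit at limits, as the limit of > 26000 nM in this assay, at which 1 of the 3 values shown sits, the limit of > 18700 nM in this assay, at which 1 of the 3 values shown sits, and the limit of > 21900 nM in this assay, at which 1 of the 3 values shown sits, show.

Compound 4 `CC(C)N(Cc1cccc(OCCCCCC(=O)O)c1)C(=O)c1ccc(-c2cccc(F)c2)cc1` is the unmeasured one. It differs from compound 2 by fluoro in place of phenoxy on an aromatic carbon. Among the measured compounds shown here, since the readable evidence offers no step of known size, the expectation rests on the fact that every compound of this core so far sat at a limit. Compound 4 is therefore expected to sit at a limit too, giving an estimated 30000 nM in this assay, within 10000 nM to 90000 nM, which means an expected step that the limit leaves unreadable from compound 2 to compound 4, essentially no change beyond the scatter.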

Compound 4, half-maximal effective concentration: > 26000 nM
Compound 4: a limit, no number; the forecaster's own chance of this, stated with the estimate: 80%; the middle value does not contradict the limit.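

In this assay compound 4 gives > 26000 nM, which is a limit and not a number. Among the compounds shown here, compounds 1, 2 and 3 also stand at limits, so no step to compound 4 can be read in size. The compounds shown leave open what concentration of any of them would reach the effect.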